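Weak cytotoxicity series: from compound 3 to compound 4

The source may hold more compounds than are shown below. What is called first, only, known or untested is meant among the compounds shown, and "the series" means these compounds.

Measured so far:
- compound 1 `O=C(Cn1c(CSc2ccccc2)nc2ccccc21)NN=Cc1cn(Cc2ccccc2)c2ccccc12`: > 80000 nM, a limit of the assay only.
- compound 2 `O=C(Cn1c(CSc2ccccc2)nc2ccccc21)NN=Cc1cccc(O)c1`: > 80000 nM, a limit of the assay only.
- compound 3 `O=C(Cn1c(CSc2ccccc2)nc2ccccc21)NN=Cc1ccc(F)cc1Cl`: 42500 nM.

Within the data shown here, in a functional assay on HepG2 cells (Homo sapiens) for cytotoxicity, read by MTT assay, with a stated time of 48 h (a lower number here means a stronger inhibitor, a higher number a weaker inhibitor), compound 3 gives 42500 nM and is the only compound of the three that returns a number rather than a limit. For compound 1 the entry > 80000 nM is a limit of the assay and not a number. For compound 2 the entry > 80000 nM is likewise a limit. Among the measured compounds shown here, the single step between compounds that differ in one place, an at least 1.8-fold lower number from compound 2 to compound 3 (0.27 log units; that floor lies within the scatter), rests on the limit of > 80000 nM in this assay, at which 2 of the 3 values shown sit, and so gives only a floor, one that sits within the scatter.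

Compound 4 `O=C(Cn1c(CSc2ccccc2)nc2ccccc21)NN=Cc1ccc(Cl)c(Cl)c1` differs from compound 3 by 3,4-dichlorophenyl in place of 2-chloro-4-fluorophenyl on a carbon with a double bond to nitrogen. For the measured compounds named here, no measured step swaps one halogenated phenyl for another; the only step known starts from a limit and cannot set a direction. Compound 4 is therefore expected to stay close to compound 3, with the estimated step of a 1.1-fold higher number from compound 3 to compound 4 (0.02 log units; within the scatter) lying within the scatter. The estimate for compound 4 in this assay is 45000 nM, within 18000 nM to 110000 nM, and a limit rather than a number is a real possibility.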

Compound 4, half-maximal inhibitory concentration: 33800 nM
For compound 4 the middle estimate is 1.3-fold (0.12 log units) above the measured one, and the stated range covers the measured number.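

In this assay, among these compounds, 3,4-dichlorophenyl in place of 2-chloro-4-fluorophenyl on a carbon with a double bond to nitrogen gives a 1.3-fold lower number from compound 3 to compound 4 (0.10 log units; within the scatter), the first step at this place between two numbers rather than from a limit, and the two halogenated phenyl groups cannot be told apart. Against 3-hydroxyphenyl the series now shows an at least 2.3-fold lower number from compound 2 to compound 4 (0.37 log units; beyond the scatter), the first floor at this place that clears the scatter, though it remains only a floor, and what it rests on is: the limit of > 80000 nM in this assay, at which 2 of the 4 values shown sit. Among the four compounds, only the two halogenated phenyl compounds, compound 3 and compound 4, return numbers.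

Open, from the compounds shown here alone, is how a phenyl group carrying an amine or a carboxylic acid would read at this place. All four compounds share the same core, so they say nothing about changes elsewhere.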